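Cyclohexyl on the ring nitrogen of a bile acid receptor agonist

The compounds below may be only part of what the source reports. "The series", "measured", "known", "first", "only" and "open" are said of these compounds alone.

Compound 1 `CC(C)c1onc(-c2c(Cl)cccc2Cl)c1COc1ccc(-c2nc3ccc(C(=O)O)cc3n2Cc2ccc(F)cc2)cc1`: 3.31 nM
Compound 2 `CC(C)c1onc(-c2c(Cl)cccc2Cl)c1COc1ccc(-c2nc3ccc(C(=O)O)cc3n2CC(C)(C)C)cc1`: 13 nM
Compound 3 `CCCC(CCC)n1c(-c2ccc(OCc3c(-c4c(Cl)cccc4Cl)noc3C(C)C)cc2)nc2ccc(C(=O)O)cc21`: 1.8 nM

In an assay on Huh-7 cells for agonist activity at Bile acid receptor (Homo sapiens), read by a luciferase reporter (on this read-out lower numbers stand for an effect already at smaller amounts and higher numbers for an effect only at larger amounts of compound), compound 1 stands second highest of the three numbers; compound 3 is within the scatter of it, while compound 2 lies beyond it with a 3.9-fold higher number from compound 1 to compound 2 (0.59 log units; beyond the scatter). Compound 4 `CC(C)c1onc(-c2c(Cl)cccc2Cl)c1COc1ccc(-c2nc3ccc(C(=O)O)cc3n2C2CCCCC2)cc1` differs from compound 1 by cyclohexyl in place of 4-fluorobenzyl on an aromatic nitrogen. Going by the values given here, two steps bear on this change: a 3.9-fold higher number from compound 1 to compound 2 (0.59 log units; beyond the scatter) and a 1.8-fold lower number from compound 1 to compound 3 (0.26 log units; within the scatter). A branched saturated group set directly on the aromatic nitrogen, as in compound 3, gave a number within the scatter of compound 1, whereas neopentyl gave a modestly higher one. Cyclohexyl is expected to behave between these, so compound 4 is expected at a 1.4-fold higher number from compound 1 to compound 4 (0.13 log units; within the scatter), estimated as 4.5 nM with a range of 1.5 nM to 13 nM.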

Compound 4, half-maximal effective concentration: 4.21 nM
The estimate for compound 4 lay 1.1-fold (0.03 log units) above the measured number; measured number inside the range.
By their numbers in this assay, from the lowest: compounds 3, 1 and 4 (each within the scatter of the next, the first and the last beyond it); then compound 2.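

Cyclohexyl in place of 4-fluorobenzyl on the aromatic nitrogen stays within the scatter, with a 1.3-fold higher number from compound 1 to compound 4 (0.10 log units; within the scatter), so an aromatic ring in this group is not needed for a number of this size. Saturated groups at this position still differ from one another, with a 2.3-fold higher number from compound 3 to compound 4 (0.37 log units; beyond the scatter) and a 3.1-fold lower number from compound 2 to compound 4 (0.49 log units; beyond the scatter). Nothing available explains these differences. Going by these compounds, whether a smaller ring such as cyclopentyl, a plain methyl, or a cyclohexyl carrying an amine would keep the number at this level remains open.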